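A few compounds are considered here, and "the series" means these few. Any claim that something is new, unique, unknown or untested is made for them only; others in the source may bear on it.

Measured so far:
compound 1, `COc1ccc(-c2ccc(CN3CCCN(C)CC3)cc2)cc1` — in an assay on isolated protein for binding affinity to choline kinase alpha (Homo sapiens), read by surface plasmon resonance (a higher number here means weaker binding, a lower number tighter binding), compound 1 gives 3800 nM
compound 2, `CN1CCCN(Cc2ccc(-c3cc(F)c(CN4CCCN(C)CC4)c(F)c3)cc2)CC1` — in this assay compound 2 gives 259 nM

Going by the values given here, of the two numbers in hand, compound 1 stands at the higher one, and the gap between compound 1 and compound 2 lies beyond the usual scatter of this assay; no single-point step connects the two, so nothing more is read from that pair than the two values themselves.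

Compound 3, `CN1CCCN(Cc2ccc(-c3ccc(N4CCN(C)CC4)cc3)cc2)CC1`, has not yet been measured in this assay. It differs from compound 1 in one place: 4-methylpiperazin-1-yl in place of methoxy on an aromatic carbon. In plain words, a 4-methylpiperazin-1-yl group takes the position of the methoxy group on that aromatic carbon, so that each end of the shared core now carries a ring containing nitrogen, as is also the case in compound 2.

On that basis a move toward tighter binding is expected, and the step from compound 1 to compound 3 is estimated at a 7.6-fold lower number from compound 1 to compound 3 (0.88 log units; beyond the scatter). The expectation rests in part on compound 2, because compound 2 gives 259 nM in this assay. For compound 3 the estimated dissociation constant is 500 nM, with an expected range from 150 nM to 1600 nM.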

Compound 3, dissociation constant: 769 nM
Estimate against measurement, compound 3: 1.5-fold (0.19 log units) below; low and high end bracket the measured number.
By their numbers in this assay, from the lowest: compound 2; then compound 3; then compound 1.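

In this assay, going by these compounds alone, putting 4-methylpiperazin-1-yl in place of methoxy gives a 4.9-fold lower number from compound 1 to compound 3 (0.69 log units; beyond the scatter), the only step here that ties a change in binding to a single place: the aromatic carbon para to a large group. It shows that this position accepts a far larger group without loss of binding, as the entering group has 7 heavy atoms and a six-membered non-aromatic ring with 2 hetero atoms, while the methoxy group that leaves has 2 heavy atoms and no ring. No measured property of these compounds accounts for the step.

The compounds shown do not tell whether the tighter binding goes with the ring, with its nitrogen atoms or simply with the added heavy atoms, since all three change together in this single step. A piperidine, a morpholine or an open-chain dimethylamino group on the same aromatic carbon would bear on that question, as would a shorter or longer chain linking the 4-methylpiperazin-1-yl ring to the shared core.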